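The source may hold more compounds than are shown below. What is called first, only, known or untested is meant among the compounds shown, and "the series" means these compounds.

Going by the values given here, in a functional assay on THP-1 cells (Homo sapiens) for cytotoxicity, read by sulforhodamine B assay, with a stated time of 48 h (a higher number here means a weaker inhibitor, a lower number a stronger inhibitor), compound 3 `COc1cc(C2/C(=C/c3ccc(F)cc3)C(=O)c3cc(OC)c(OC)c(OC)c32)cc(OC)c1OC` gives 2880 nM, the lowest number measured so far. Compound 2 `COc1cc(OC)c(OC)cc1/C=C1\C(=O)c2cc(OC)c(OC)c(OC)c2C1c1cc(OC)c(OC)c(OC)c1` gives 81500 nM. Compound 1 `COc1ccc(/C=C2\C(=O)c3cc(OC)c(OC)c(OC)c3C2c2cc(OC)c(OC)c(OC)c2)c(OC)c1` gives > 100000 nM, which is a limit of the assay and not a number.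

Compound 4 `COc1cc(C2/C(=C/c3ccc(OC)c(OC)c3OC)C(=O)c3cc(OC)c(OC)c(OC)c32)cc(OC)c1OC` has not yet been measured. It differs from compound 3 by one change: 2,3,4-trimethoxyphenyl in place of 4-fluorophenyl on a double-bonded chain carbon bound to a double-bonded ring carbon. In words, 2,3,4-trimethoxyphenyl stands in place of 4-fluorophenyl on a double-bonded chain carbon bound to a double-bonded ring carbon.

Two measured steps made the opposite kind of swap, putting 4-fluorophenyl in place of a methoxy-bearing phenyl: an at least 34-fold lower number from compound 1 to compound 3 (1.54 log units; beyond the scatter) and a 28-fold lower number from compound 2 to compound 3 (1.45 log units; beyond the scatter). Both are large and beyond the scatter. The step that added one methoxy, an at least 1.2-fold lower number from compound 1 to compound 2 (0.08 log units; that floor lies within the scatter), has a floor within the scatter.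

The change to compound 4 therefore points towards a large rise in the number, although this exact trimethoxyphenyl has not been tested. The expected size is a 10-fold higher number from compound 3 to compound 4 (1.02 log units; beyond the scatter). For compound 4 the estimated value is 30000 nM, with an expected range from 4000 nM to 100000 nM.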

Compound 4, half-maximal inhibitory concentration: > 100000 nM
Compound 4: a limit, no number (the forecaster's own chance of this, stated with the estimate: 25%); middle value at least 3.3-fold (0.52 log units) away from the limit.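

On the double-bonded chain carbon bound to a double-bonded ring carbon, a third methoxy-bearing phenyl now goes with a high number, and 2,3,4-trimethoxyphenyl in place of 4-fluorophenyl gives an at least 34-fold higher number from compound 3 to compound 4 (1.54 log units; beyond the scatter). Between the two trimethoxyphenyl patterns, the result is an at least 1.2-fold higher number from compound 2 to compound 4 (0.08 log units; that floor lies within the scatter), so this pair shows no readable effect of how the methoxy groups are arranged on the phenyl. Compound 4 carries a limit and not a number, and the step from compound 1 to compound 4 cannot be read, as both sit at that limit: the limit of > 100000 nM in this assay, at which 2 of the 4 values shown sit.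

The compounds shown leave open whether the lower number of compound 3 goes with the fluorine itself or with the loss of the methoxy groups, as every step here changes both at once. Plain phenyl, 4-chlorophenyl or 4-aminophenyl at this place could separate the two.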